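This account rests on a few compounds, and the source may have more. Where it says the series, first, only, none or still open, it means among the compounds named here.

Compound 1 `COc1cc(-c2cccc3nc(-c4cccc(F)c4)oc23)cc(OC)c1OC`: > 25000 nM
Compound 2 `COc1cc(-c2cccc3nc(-c4cccc(Cl)c4)oc23)cc(OC)c1OC`: > 25000 nM
Compound 3 `COc1cc(-c2cccc3nc(-c4ccc5cc[nH]c5c4)oc23)cc(OC)c1OC`: > 25000 nM

These three compounds were tested in a functional assay on MCF7 cells (Homo sapiens) for antiproliferative activity, read by MTT assay, with a stated time of 48 h; on this read-out lower numbers stand for stronger inhibition and higher numbers for weaker inhibition. Compound 3 gives > 25000 nM, which is a limit and not a number. The whole set shares that result, with the limit of > 25000 nM in this assay, at which 3 of the 3 values shown sit. Nothing therefore places compound 3 above or below the other two.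

Compound 4 `COc1cc(-c2cccc3nc(-c4ccco4)oc23)cc(OC)c1OC` has not yet been measured. Its difference from compound 3 is counted here: furan-2-yl in place of 1H-indol-6-yl on an aromatic carbon. Put simply, it carries furan-2-yl in place of 1H-indol-6-yl on an aromatic carbon of the shared core.

Two measured changes bear on that same carbon: a step that the two limits leave unreadable from compound 1 to compound 3 and a step that the two limits leave unreadable from compound 2 to compound 3. Going by the values given here, neither has a readable size, so they offer no measured step to scale from, and no direction of change in this assay can be expected with confidence. What they do show is that three different groups there all end at the limit.

With compound 3 at > 25000 nM, a limit, compound 4 is expected to be reported as a limit too. The expected step is a number no higher from compound 3 to compound 4 (the limit leaves the size open), and this is only an estimate. For compound 4 the estimated value is 25000 nM, with an expected range from 10000 nM to 50000 nM.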

Compound 4, half-maximal inhibitory concentration: > 25000 nM
Compound 4: a limit, no number; the forecaster's own chance of this, stated with the estimate: 80%; the middle value sits exactly at the limit.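

In this assay compound 4 gives > 25000 nM, which is a limit and not a number. No new step can be read from compound 4 to compound 1, compound 2 or compound 3, because all four end at the same limit: the limit of > 25000 nM in this assay, at which 4 of the 4 values shown sit. The compounds shown leave open how these four differ in strength and whether any group on this carbon gives a readable value in this assay.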